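The compounds below may be only part of what the source reports. "The series", "measured", "known", "first", "only" and "open" are said of these compounds alone.

Going by the values given here, compound 1 `CC(C(=O)NCc1ccc(C(F)(F)F)cc1N1CCCCCC1)c1ccc(NS(C)(=O)=O)c(F)c1` holds the lower of the two numbers measured so far in an assay on CHO cells for antagonist activity at transient receptor potential cation channel subfamily V member 1 (Homo sapiens), read by FLIPR (on this read-out higher numbers stand for weaker inhibition and lower numbers for stronger inhibition), where compound 1 gives 1.6 nM; compound 2 `Cc1cccc(N2CCN(c3cc(C(F)(F)F)ccc3CNC(=O)C(C)c3ccc(NS(C)(=O)=O)c(F)c3)CC2)c1` gives 1.8 nM in this assay, and the gap between the two lies within the scatter. Compound 3 `CC(C(=O)NCc1ccc(C(F)(F)F)cc1OC1CCCCC1)c1ccc(NS(C)(=O)=O)c(F)c1` has not yet been measured. It differs from compound 1 in one place: cyclohexyloxy in place of azepan-1-yl on an aromatic carbon. Among the compounds with values here, no measured pair shows this change, so the step from compound 1 to compound 3 is expected to be small, most likely toward a slightly higher number and possibly not beyond the scatter, a 2.0-fold higher number from compound 1 to compound 3 (0.30 log units; within the scatter). For compound 3 the expected value in this assay is 3.2 nM, within a range from 1 nM to 12 nM.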

Compound 3, inhibition constant: 0.7 nM
Compound 3: the middle estimate sits 4.6-fold (0.66 log units) above what was measured; the whole stated range lies above it.
By their numbers in this assay, from the lowest: compound 3; then compounds 1 and 2 (each within the scatter of the next).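

At this aromatic carbon, ortho to a large group and meta to a trifluoromethyl group, cyclohexyloxy in place of azepan-1-yl gives a 2.3-fold lower number from compound 1 to compound 3 (0.36 log units; beyond the scatter) in this assay. The position thus accepts a six-membered carbon ring joined through oxygen as well as the seven-membered ring joined through nitrogen, and the swap shifts the number beyond the scatter. Nothing available accounts for this shift.

The change alters the linking atom and the ring together, and the compounds shown do not separate the two. As far as these compounds go, how piperidin-1-yl, cyclopentyloxy or an open-chain butoxy would read at this carbon remains open.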